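From dimethylamino to 4-methylpiperazin-1-yl on compound 1

The source may hold more compounds than are shown below. What is called first, only, known or untested is meant among the compounds shown, and "the series" means these compounds.

Compound 1 `Cc1ccc(S(=O)(=O)Nc2ccc(CNc3nc(N(C)C)nc4ccccc34)cc2)cc1` gives 11000 nM
Compound 2 `CN(C)c1nc(NCc2ccc(NC(=O)c3ccncc3)cc2)c2ccccc2n1` gives 15000 nM
Compound 3 `Cc1ccc2nc(N3CCNC(C)C3)nc(NCc3ccc(C(=O)NC4CCN(Cc5ccc(F)cc5)CC4)cc3)c2c1` gives 2000 nM

In a functional assay on HCT-116 cells (Homo sapiens) for inhibition, read by luminescence and resazurin assay, with a stated time of 3 days (on this read-out lower numbers stand for stronger inhibition and higher numbers for weaker inhibition), compound 1 sits within the scatter of compound 2, while compound 3 stands apart from compound 1 with a number beyond the scatter on the lower, stronger side. Compound 4 `Cc1ccc(S(=O)(=O)Nc2ccc(CNc3nc(N4CCN(C)CC4)nc4ccccc34)cc2)cc1` keeps all of compound 1 except one group. It carries 4-methylpiperazin-1-yl in place of dimethylamino on an aromatic carbon, between two ring nitrogen atoms, and the full count of that swap is 4-methylpiperazin-1-yl in place of dimethylamino on an aromatic carbon in all.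

Going by the values given here, no measured step changes this group. Among the compounds with values here, the one measured step is a 1.4-fold higher number from compound 1 to compound 2 (0.13 log units; within the scatter) and it concerns a different group, so it gives no direct guide to size. Compound 3 with 2000 nM does carry a six-membered non-aromatic ring with 2 hetero atoms on an aromatic carbon. It also differs from compound 1 in several other places, so it offers only a weak hint toward a lower number.

A small move in that direction is therefore expected, and it may well stay within the scatter. The expected step is a 1.8-fold lower number from compound 1 to compound 4 (0.26 log units; within the scatter) on this estimate. For compound 4 the estimated value is 6000 nM with an expected range from 2000 nM to 15000 nM until the measurement is known.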

Compound 4, half-maximal inhibitory concentration: > 20000 nM
Compound 4: a limit, no number (the forecaster's own chance of this, stated with the estimate: 10%); at least 3.3-fold (0.52 log units) between middle value and limit.
By their numbers in this assay, from the lowest: compound 3; then compounds 1 and 2 (each within the scatter of the next). At a limit, above all of these: compound 4.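

In this assay compound 4 gives > 20000 nM, which is a limit of the assay and not a number. Going by these compounds alone, the swap of dimethylamino for 4-methylpiperazin-1-yl, on the aromatic carbon between two ring nitrogen atoms, gives an at least 1.8-fold higher number from compound 1 to compound 4 (0.25 log units; that floor lies within the scatter), and this is the first direct reading of a change at this position, with no sign of the lower number that a ring here might have promised. Even so, the size of the step can be stated only as a floor, and the reading of this position rests on a single entry: the limit of > 20000 nM in this assay, at which 1 of the 4 values shown sits.

The compounds shown leave open how far compound 4 really lies from compound 1, and whether the outcome goes with the ring, with its second nitrogen or with its added methyl. Morpholin-4-yl or piperazin-1-yl on the same aromatic carbon, each set on the rest of compound 1, would begin to separate these parts, and a small primary amine there would show what happens when the group shrinks rather than grows.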